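The source may hold more compounds than are shown below. What is called first, only, known or untested is meant among the compounds shown, and "the series" means these compounds.

Compound 1 `CC(C)(C)NCc1c(C(=O)O)nn(-c2ccccc2)c1-c1ccc(Br)cc1`: > 585000 nM
Compound 2 `COc1ccc(-c2c(CNC(C)(C)C)c(C(=O)O)nn2-c2ccccc2)cc1`: > 659000 nM

In a functional assay on OVCAR-3 cells (Homo sapiens) for inhibition, read by sulforhodamine B assay, with a stated time of 48 h (on this read-out higher numbers stand for weaker inhibition of growth and lower numbers for stronger inhibition of growth), compound 2 gives > 659000 nM, which is a limit and not a number. Compound 1 gives > 585000 nM, also a limit. Compound 3 `CC(C)(C)NCc1c(C(=O)O)nn(-c2ccccc2)c1-c1ccc([N+](=O)[O-])cc1` has nitro in place of methoxy on an aromatic carbon of compound 2: nitro in place of methoxy on an aromatic carbon. Among the compounds with values here, the only measured change at this place, a step that the two limits leave unreadable from compound 1 to compound 2, supplies no size to carry over. With compound 1 and compound 2 both reported as limits, no step beyond the scatter is expected in this assay, and another limit is likely. The expected result is an at least 1.0-fold lower number from compound 2 to compound 3 (0.01 log units; that floor lies within the scatter). Compound 3 is estimated at 630000 nM, with an expected range from 350000 nM to 900000 nM.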

Compound 3, concentration for 50% growth inhibition: > 634000 nM
Compound 3: a limit, no number (the forecaster's own chance of this, stated with the estimate: 85%); middle value at least 1.0-fold (0.00 log units) away from the limit.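

Compound 1, compound 2 and compound 3 all give limits, not numbers, in this assay, and the steps between them cannot be read. Going by these compounds, whether bromo, methoxy or nitro makes any difference to growth inhibition stays open.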